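Solubility Series: Two Parallel Ring Swaps on a Shared Core

The source may report more compounds than this note shows. Statements on the series, on what has been measured and on what is new or still open speak of the compounds shown alone.

Measured compounds:
compound 1 `CC(C)(C)c1ccc(-c2ccc3c(NCCCNCc4ccco4)ccnc3c2)cc1`: 32000 nM
compound 2 `Clc1ccc(Oc2ccc3c(NCCCNCc4ccco4)ccnc3c2)cc1`: 14500 nM
compound 3 `COc1ccc(F)cc1CNCCCNc1ccnc2cc(Oc3ccc(Cl)cc3)ccc12`: 14500 nM

Three compounds have been run in a physicochemical assay for solubility, with a stated time of 18 h, at pH 7.4; on this read-out higher numbers stand for higher solubility and lower numbers for lower solubility. Compound 1 `CC(C)(C)c1ccc(-c2ccc3c(NCCCNCc4ccco4)ccnc3c2)cc1` gives 32000 nM in this assay. Compound 2 `Clc1ccc(Oc2ccc3c(NCCCNCc4ccco4)ccnc3c2)cc1` gives 14500 nM. Compound 3 `COc1ccc(F)cc1CNCCCNc1ccnc2cc(Oc3ccc(Cl)cc3)ccc12` gives 14500 nM, level with compound 2 at the digits reported; together these two sit at the low end of the three numbers.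

Compounds 2 and 1 differ in one place: 4-(tert-butyl)phenyl in place of 4-chlorophenoxy on an aromatic carbon. This assay moved a 2.2-fold higher number from compound 2 to compound 1 (0.34 log units; beyond the scatter). Compounds 2 and 3 differ elsewhere, in the cores that the next pair will carry: 5-fluoro-2-methoxyphenyl in place of furan-2-yl on a saturated chain carbon bound to an amine nitrogen. That change gave no change at the digits printed from compound 2 to compound 3 (within the scatter).

Compound 4 `COc1ccc(F)cc1CNCCCNc1ccnc2cc(-c3ccc(C(C)(C)C)cc3)ccc12` has not yet been measured. It differs from compound 3 by 4-(tert-butyl)phenyl in place of 4-chlorophenoxy on an aromatic carbon. This is the same change as the one made from compound 2 to compound 1, made once before among the compounds shown and recurring here on the core of compound 3. The place of the change reads the same in both pairs, so it is taken as the same change rather than merely the same kind.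

Set beside the earlier step, the expected step from compound 3 to compound 4 in this assay is estimated as a 2.1-fold higher number from compound 3 to compound 4 (0.32 log units; beyond the scatter), resting on the single prior instance a 2.2-fold higher number from compound 2 to compound 1 (0.34 log units; beyond the scatter) and on the level footing of compound 2 and compound 3 at 14500 nM. Whether a change of core from furan-2-yl to 5-fluoro-2-methoxyphenyl alters the size of this step cannot be read from one example.

Compound 4 is estimated at 30000 nM in this assay, with a range expected from 14000 nM to 65000 nM.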

Compound 4, solubility: 32000 nM
Beside the measured number, compound 4's estimate is 1.1-fold (0.03 log units) below it, and the stated range covers the measured number.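

In this assay, 4-(tert-butyl)phenyl in place of 4-chlorophenoxy gave a 2.2-fold higher number from compound 3 to compound 4 (0.34 log units; beyond the scatter) on the core of compound 3, and the same change gave a 2.2-fold higher number from compound 2 to compound 1 (0.34 log units; beyond the scatter) on the core of compound 2, so in these two pairs the step carried over with its size intact. The other edge of the set agrees: 5-fluoro-2-methoxyphenyl in place of furan-2-yl gave no change at the digits printed from compound 1 to compound 4 (within the scatter) with 4-(tert-butyl)phenyl in place, just as it left compound 2 and compound 3 level with 4-chlorophenoxy in place, so across these four compounds the two changes read as independent of each other, but two cores and one pair of groups make only a single repeat and do not establish a rule for the series. Nothing at hand bears on why the step has this size or why it repeats.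

Still open, from the compounds shown here alone, is whether the step keeps its size when the group on the chain amine is something further afield, such as a carboxylic acid or a morpholine in place of furan-2-yl or 5-fluoro-2-methoxyphenyl. Equally open, going by these compounds, is how the series reads with a longer chain joining the two amine nitrogens, or with a pyridine ring in place of 4-(tert-butyl)phenyl on the aromatic carbon.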